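From a Ketone to a Diol: What to Expect of Compound 4

This account rests on a few compounds, and the source may have more. Where it says the series, first, only, none or still open, it means among the compounds named here.

Compound 1 `CC(C)[C@@H](O)C(=O)c1c[nH]c2ccccc12`: > 10000 nM
Compound 2 `CC(C)(O)C(=O)Cc1cn([C@@H]2O[C@H](CO)[C@@H](O)[C@H](O)[C@H]2O)c2ccccc12`: > 10000 nM
Compound 3 `CC(C)(O)[C@@H](O)C[C@]1(O)C(=O)N([C@@H]2O[C@H](CO)[C@@H](O)[C@H](O)[C@H]2O)c2ccccc21`: > 10000 nM

All three measured compounds were tested in a functional assay on Bel-7402 cells (Homo sapiens) for cytotoxicity, read by MTT assay; on this read-out higher numbers stand for weaker inhibition and lower numbers for stronger inhibition. Compound 1 gives > 10000 nM, which is a limit of the assay rather than a number. Compound 2 gives > 10000 nM, again a limit. Compound 3 gives > 10000 nM, also a limit. Compound 2 therefore stands exactly where every measured compound stands, at the limit of > 10000 nM in this assay, at which 3 of the 3 values shown sit; no finite value separates it from compound 1 or compound 3.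

Compound 4 `CC(C)(O)[C@@H](O)Cc1cn([C@@H]2O[C@H](CO)[C@@H](O)[C@H](O)[C@H]2O)c2ccccc12` has not yet been measured. It differs from compound 2 in a single place: 1,2-dihydroxy-2-methylpropyl in place of (1-hydroxy-1-methylethyl)carbonyl on a saturated chain carbon bound to an aromatic carbon. The carbonyl of the leaving group gives way to a hydroxy group with a defined stereocentre; everything else stays the same.

Going by the values given here, no step between measured compounds can be read, since all three sit at the limit. With every neighbour at the limit, the expected step in this assay a step that the limit leaves unreadable from compound 2 to compound 4 is none beyond the scatter. Compound 4 is expected to give about 15000 nM, in the range 5000 nM to 50000 nM, most likely reported once more only as a limit.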

Compound 4, half-maximal inhibitory concentration: > 10000 nM
Compound 4: no number, only a limit; the forecaster's own chance of this, stated with the estimate: 85%; the middle value does not contradict the limit.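

Compound 2 and compound 4 are each reported only as a limit, so no step can be read between them: the limit of > 10000 nM in this assay, at which 4 of the 4 values shown sit.

The compounds shown leave open what finite value any of them would give, and whether the 2,3-dihydroxy-3-methylbutyl chain of compound 4 changes anything at all.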